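Chromone-imidazole series: cytotoxicity notes toward compound 4

The compounds below may be only part of what the source reports. "The series", "measured", "known", "first", "only" and "open" are said of these compounds alone.

The series shares one core, carried through compound 1 `Cc1cc2occ(-c3nc(-c4ccccc4)c(-c4ccccc4)n3-c3ccccc3Cl)c(=O)c2cc1Cl`, compound 2 `Cc1cc2occ(-c3nc(-c4ccccc4)c(-c4ccccc4)n3-c3ccc(Cl)c(Cl)c3)c(=O)c2cc1Cl` and compound 3 `Cc1cc2occ(-c3nc(-c4ccccc4)c(-c4ccccc4)n3-c3cccc([N+](=O)[O-])c3)c(=O)c2cc1Cl`, which differ only in the aryl group on the aromatic nitrogen. In an ADME assay on MCF-10A cells (Homo sapiens) for cytotoxicity, read by MTT assay, with a stated time of 72 h (on this read-out lower numbers stand for stronger inhibition and higher numbers for weaker inhibition), compound 2 gives 98000 nM, a weak effect. For compound 1 the entry in this assay reads "not determined" (no result reported). For compound 3 the entry in this assay reads "not determined" (no result reported), so compound 3 stands without a number, as does one further member of the set.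

Compound 4 `Cc1cc2occ(-c3nc(-c4ccccc4)c(-c4ccccc4)n3-c3ccc(Cl)cc3)c(=O)c2cc1Cl` is the next member to be run in this assay. Relative to compound 3 the change is 4-chlorophenyl in place of 3-nitrophenyl on an aromatic nitrogen. Among the compounds with values here, no measured step between two members is available, so the size of this step cannot be read from the data; the only anchor is compound 2, whose value in this assay is weak. Given that anchor, the expected step from compound 3 to compound 4 is none that would be resolved beyond the scatter, and compound 4 is expected to sit in the same weak region as compound 2.

Compound 4 is thus estimated to give about 100000 nM in this assay, with a plausible range from 40000 nM to 250000 nM, and a fair chance that only a limit is reported.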

Compound 4, half-maximal inhibitory concentration: 92000 nM
Estimate against measurement, compound 4: 1.1-fold (0.04 log units) above; low and high end bracket the measured number.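

In this assay, the series now has its first readable step, a 1.1-fold lower number from compound 2 to compound 4 (0.03 log units; within the scatter), which shows that hydrogen in place of chloro on an aromatic carbon of the aryl group on the aromatic nitrogen leaves the number within the scatter, with both compounds in the weak region. Steps involving compound 1 or compound 3 cannot be read, since neither has a single number in this assay, so the exchange of 3-nitrophenyl for 4-chlorophenyl has no measured size. No supporting data bear on why this single chloro exchange leaves the read-out within the scatter.

The compounds shown leave open whether an aryl group carrying an amine or a carboxylic acid, or a longer alkyl chain in place of the aryl group on the aromatic nitrogen, would move the number out of the weak region. With one readable step, confined to chloro and hydrogen on this aryl group, they also leave open whether any exchange at this position gives a step beyond the scatter.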